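A few compounds are considered here, and "the series" means these few. Any claim that something is new, unique, unknown or untested is made for them only; others in the source may bear on it.

Of the compounds shown here, three built on one shared core have been measured in a functional assay on HeLa cells (Homo sapiens) for antiproliferative activity, read by CCK-8 assay, with a stated time of 72 h; on this read-out higher numbers stand for weaker inhibition and lower numbers for stronger inhibition. Compound 1 `COc1ccc(C(=O)Nc2cccc(-c3oc4cc(-c5ccc(F)cc5)ccc4c(=O)c3O)c2)cc1` gives 4820 nM, compound 2 `O=C(Nc1cccc(-c2oc3cc(-c4ccc(F)cc4)ccc3c(=O)c2O)c1)c1cccc(F)c1` gives 8780 nM, and compound 3 `O=C(Nc1cccc(-c2oc3cc(-c4ccc(F)cc4)ccc3c(=O)c2O)c1)c1ccc([N+](=O)[O-])cc1` gives 12300 nM, which is the highest of the three numbers. Two of the steps between them, a 1.8-fold higher number from compound 1 to compound 2 (0.26 log units; within the scatter) and a 1.4-fold higher number from compound 2 to compound 3 (0.15 log units; within the scatter), stay within the scatter. Compound 4 `CCCc1ccc(C(=O)Nc2cccc(-c3oc4cc(-c5ccc(F)cc5)ccc4c(=O)c3O)c2)cc1` differs from compound 3 by propyl in place of nitro on an aromatic carbon. Within the data shown here, the one measured step that also swaps the group on that aromatic carbon is a 2.6-fold higher number from compound 1 to compound 3 (0.41 log units; beyond the scatter), where the nitro gave the higher number, so a move back toward the numbers of compound 1 and compound 2 is expected, a 2.1-fold lower number from compound 3 to compound 4 (0.31 log units; beyond the scatter). Compound 4 is therefore estimated at 6000 nM in this assay, with a range from 2500 nM to 15000 nM.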

Compound 4, half-maximal inhibitory concentration: 8790 nM
For compound 4 the middle estimate is 1.5-fold (0.17 log units) below the measured one; the range from low to high includes it.
By their numbers in this assay, from the lowest: compounds 1, 2, 4 and 3 (each within the scatter of the next, the first and the last beyond it).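

Propyl and nitro, which differ in hydrogen-bond acceptors (none against two), are not told apart on this aromatic carbon (a 1.4-fold lower number from compound 3 to compound 4 (0.15 log units; within the scatter)). Propyl also lies within the scatter of methoxy (a 1.8-fold higher number from compound 1 to compound 4 (0.26 log units; within the scatter)), so compound 4 bridges compound 1 and compound 3, the only pair here that stands beyond the scatter. Its 4-propylphenyl group likewise matches the 3-fluorophenyl group (a 1.0-fold higher number from compound 2 to compound 4 (0.00 log units; within the scatter)), and no supporting measurement offers a reason for any of this. On these data alone, whether an amine, a carboxylic acid or a chain longer than propyl at this position would separate clearly from these numbers remains open.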